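Extending the saturated chain: working notes on compound 3

The source may hold more compounds than are shown below. What is called first, only, known or untested is meant among the compounds shown, and "the series" means these compounds.

Measured in a functional assay, with a stated time of 10 min; on this read-out lower numbers stand for stronger inhibition and higher numbers for weaker inhibition:
- compound 1 `CCCCCCOc1cc(OC)ccc1C(C)=O`: 84400000 nM
- compound 2 `CCCCCCCCOc1cc(OC)ccc1C(C)=O`: 69400000 nM

Compound 2 stands level with compound 1 within the scatter, so no order can be drawn between the two. Only these two compounds have been measured, which leaves little to compare it against.

The next compound is compound 3 `CCCCCCCCCCOc1cc(OC)ccc1C(C)=O`. The change is ethyl in place of hydrogen on a saturated chain carbon, eight bonds along the chain from an oxygen on an aromatic ring.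

Within the data shown here, one measured step bears on this: a 1.2-fold lower number from compound 1 to compound 2 (0.08 log units; within the scatter). It is the same replacement six bonds along the chain, and it stays within the scatter. One step is thin support, but in this assay no change beyond the scatter is expected. The expected change is a 1.2-fold lower number from compound 2 to compound 3 (0.06 log units; within the scatter). For compound 3 the estimated value is 60000000 nM, with an expected range from 28000000 nM to 120000000 nM.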

Compound 3, half-maximal inhibitory concentration: 57400000 nM
Compound 3: middle estimate off by 1.0-fold (0.02 log units), on the high side, and the stated range covers the measured number.
By their numbers in this assay, from the lowest: compounds 3, 2 and 1 (each within the scatter of the next).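

In this assay, the same ethyl in place of hydrogen, now on a saturated chain carbon eight bonds along the chain from an oxygen on an aromatic ring, gives a 1.2-fold lower number from compound 2 to compound 3 (0.08 log units; within the scatter) and so again produces no readable change. The two extensions taken together, read as butyl in place of hydrogen on a saturated chain carbon six bonds along the chain from an oxygen on an aromatic ring, give a 1.5-fold lower number from compound 1 to compound 3 (0.17 log units; within the scatter) and so also stay level, which means that compounds 1, 2 and 3 show no trend with chain length. No measured evidence is available to explain this flat result.

On these data alone, whether a longer chain would move the number beyond the scatter remains open. So does the effect of a chain ending in an amine or a carboxylic acid, and of any change to the shared core.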